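A few compounds are considered here, and "the series" means these few. Any claim that something is new, unique, unknown or untested is made for them only; others in the source may bear on it.

Measured so far:
- compound 1 `O=C1c2ccccc2C(=O)N1C/C=C\Cn1cc(C#Cc2ccc(Br)cc2)c(=O)[nH]c1=O`; in a functional assay on MOLT-4 cells (Homo sapiens) for antiproliferative activity, read by MTT assay, with a stated time of 3 days (a lower number here means a stronger inhibitor, a higher number a weaker inhibitor), compound 1 gives 89000 nM
- compound 2 `CCCCCCC#Cc1cn(C/C=C/CN2C(=O)c3ccccc3C2=O)c(=O)[nH]c1=O`; in this assay compound 2 gives 35000 nM

Of these two numbers, compound 1 stands highest; compound 2 sits lower by a margin beyond the usual scatter. Compound 3 `CCCCc1ccc(C#Cc2cn(C/C=C\CN3C(=O)c4ccccc4C3=O)c(=O)[nH]c2=O)cc1` differs from compound 1 in a single place: butyl in place of bromo on an aromatic carbon. Among the compounds with values here, no step between measured compounds mirrors this change, so any expectation rests on the two values alone. Compound 3 is expected to come in somewhat lower, a step of a 1.8-fold lower number from compound 1 to compound 3 (0.25 log units; within the scatter) in this assay, though a result within the scatter would not be surprising. The estimate for compound 3 is 50000 nM, with a range from 15000 nM to 150000 nM.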

Compound 3, half-maximal inhibitory concentration: 31000 nM
For compound 3 the middle estimate is 1.6-fold (0.21 log units) above the measured one; the range from low to high includes it.
By their numbers in this assay, from the lowest: compounds 3 and 2 (each within the scatter of the next); then compound 1.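

Within the data shown here, replacing 4-bromophenyl with 4-butylphenyl gives the first direct reading at this position: in this assay, the step is a 2.9-fold lower number from compound 1 to compound 3 (0.46 log units; beyond the scatter), a modest move towards stronger inhibition that lies beyond the scatter. This aromatic carbon therefore tolerates butyl, which has more heavy atoms than bromo, with no loss of antiproliferative activity. As far as these compounds go, whether an amine, a carboxylic acid or a longer chain at this carbon would lower the number further remains open. Nothing given here accounts for the step.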